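This account rests on a few compounds, and the source may have more. Where it says the series, first, only, none or still open, it means among the compounds named here.

In a functional assay on the whole organism (strain Sprague-Dawley) for inhibition, with Rattus norvegicus as the target (on this read-out higher numbers stand for an effect only at larger amounts of compound and lower numbers for an effect already at smaller amounts), compound 2 `O=c1c(-c2nn[nH]n2)c[nH]c2c(Br)cccc12` gives only a limit, > 10 mg/kg, and no number. Compound 4 `Cc1cccc2c(=O)c(-c3nn[nH]n3)c[nH]c12` keeps the core of compound 2 and differs in one place: methyl in place of bromo on an aromatic carbon. Within the data shown here, only one measured step exists for comparison, and it concerns another pair. Compound 1 `COc1cccc2cc(-c3nn[nH]n3)cnc12` gives > 25 mg/kg in this assay, again a limit rather than a number. Compound 3 `CCc1cccc2cc(-c3nn[nH]n3)cnc12` gives 5 mg/kg, and the step of an at least 5.0-fold lower number from compound 1 to compound 3 (0.69 log units; beyond the scatter) shows that ethyl in place of methoxy on an aromatic carbon can move the number beyond the scatter. Going by these compounds, that swap differs from the one at hand, so the direction remains open. Compound 4 is expected to give about 10 mg/kg, between 3 mg/kg and 30 mg/kg. The expected step is a number no higher from compound 2 to compound 4 (the limit leaves the size open).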

Compound 4, minimum effective dose: > 10 mg/kg
Compound 4 was reported as a limit; the forecaster's own chance of this, stated with the estimate: 50%; the middle value lies on the limit itself.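

Among these compounds, compound 2 and compound 4 are both reported only as limits, not numbers, so no step between them can be read. The compounds shown leave open whether methyl in place of bromo changes the minimum effective dose at all.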